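From trifluoromethyl to acetamido: estimating compound 3

The source may hold more compounds than are shown below. What is called first, only, known or untested is meant among the compounds shown, and "the series" means these compounds.

In a functional assay on SMMC-7721 cells (Homo sapiens) for cytotoxicity, read by MTT assay, with a stated time of 24 h (on this read-out lower numbers stand for stronger inhibition and higher numbers for weaker inhibition), compound 1 (`O=C1/C(=C/c2cccnc2)CN(S(=O)(=O)c2ccc(C(F)(F)F)cc2)C/C1=C\c1ccccc1F`) gives 7900 nM and compound 2 (`O=C1/C(=C/c2cccnc2)CN(S(=O)(=O)c2ccc(C(F)(F)F)cc2)C/C1=C\c1ccccc1C(F)(F)F`) gives 1730 nM, so compound 2 holds the lower of the two numbers and the stronger result so far. Compound 3 (`CC(=O)Nc1ccc(S(=O)(=O)N2C/C(=C\c3cccnc3)C(=O)/C(=C/c3ccccc3C(F)(F)F)C2)cc1`) keeps the rest of compound 2 and alters one group: acetamido in place of trifluoromethyl on an aromatic carbon. Put simply, 4-(trifluoromethyl)phenyl becomes 4-acetamidophenyl.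

Within the data shown here, only one measured step can serve as a guide, and it is an indirect one. That step, a 4.6-fold lower number from compound 1 to compound 2 (0.66 log units; beyond the scatter), brought in a trifluoromethyl group at a different place in the molecule. Among the measured compounds shown here, compounds 1 and 2 carry the same 4-(trifluoromethyl)phenyl group, so no measurement yet tests a change at this spot. Here a trifluoromethyl group leaves instead, so a modest move towards a higher number is the cautious expectation, though the direction remains uncertain. The estimated change is a 1.8-fold higher number from compound 2 to compound 3 (0.27 log units; within the scatter) in this assay. For compound 3 the expected value is 3200 nM, with an estimated range from 1000 nM to 10000 nM.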

Compound 3, half-maximal inhibitory concentration: 9830 nM
For compound 3 the middle estimate is 3.1-fold (0.49 log units) below the measured one, and the stated range covers the measured number.
By their numbers in this assay, from the lowest: compound 2; then compounds 1 and 3 (each within the scatter of the next).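

In this assay, the change from 4-(trifluoromethyl)phenyl to 4-acetamidophenyl gives a 5.7-fold higher number from compound 2 to compound 3 (0.75 log units; beyond the scatter), so this end of the molecule does matter to the result, something compounds 1 and 2 could not show because they carry the same group there. Trifluoromethyl and acetamido both count 4 heavy atoms, yet acetamido brings 1 hydrogen-bond donor and 1 hydrogen-bond acceptor that trifluoromethyl lacks, so an equal heavy-atom count at this spot does not ensure an equal result. Nothing measured here explains why the number rises, and this single step cannot show which feature of the acetamido group is responsible.

From the compounds shown here alone, it remains open how other groups on the same aromatic carbon would behave, such as a plain amine, a carboxylic acid or a longer chain, and whether any of them could give a lower number than compound 2 does. Going by these compounds, it is also open whether the same swap would have a similar effect in a compound with a different group elsewhere, such as the fluoro group of compound 1.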